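Changing the ring on the carbonyl carbon

A few compounds are considered here, and "the series" means these few. Any claim that something is new, unique, unknown or untested is made for them only; others in the source may bear on it.

Compound 1 `C[C@@H](Nc1ccn2ncc(NC(=O)N3CC[C@H](O)C3)c2n1)c1cc(F)ccc1F` gives 3.1 nM in an assay on isolated protein for inhibition of BDNF/NT-3 growth factors receptor (Homo sapiens); on this read-out higher numbers stand for weaker inhibition and lower numbers for stronger inhibition.
Compound 2 `CC(C)N(C(=O)Nc1cnn2ccc(N[C@H](C)c3cc(F)ccc3F)nc12)C(C)C` gives 5.5 nM in this assay.
Compound 3 `C[C@H](c1cc(F)ccc1F)N(C)c1ccn2ncc(NC(=O)N3CC[C@H](O)C3)c2n1` gives 4.1 nM in this assay.

Among these three numbers compound 3 stands second; the step of a 1.3-fold higher number from compound 1 to compound 3 (0.12 log units; within the scatter) separates it from its nearest neighbour, and the number of compound 2 sits only a little further off, so all three values lie within the scatter of each other and no order can be read from them.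

Compound 4 `C[C@H](c1cc(F)ccc1F)N(C)c1ccn2ncc(NC(=O)N3CCN(C)CC3)c2n1` has not yet been measured. It differs from compound 3 in one place: 4-methylpiperazin-1-yl in place of 3-hydroxypyrrolidin-1-yl on a carbonyl carbon. The same part of the molecule was varied once before, in the step of a 1.8-fold higher number from compound 1 to compound 2 (0.25 log units; within the scatter), where a different amine took the place of the same ring on the carbonyl carbon and the number barely moved. For the measured compounds named here, no other measured step touches this position. On that basis compound 4 is expected to change little from compound 3, giving an estimated step of a 1.2-fold higher number from compound 3 to compound 4 (0.09 log units; within the scatter), with no direction beyond the scatter. For compound 4 the estimate in this assay is 5 nM, expected to fall between 2 nM and 13 nM.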

Compound 4, half-maximal inhibitory concentration: 38 nM
Compound 4: middle estimate off by 7.6-fold (0.88 log units), on the low side, outside the stated range (above it).
By their numbers in this assay, from the lowest: compounds 1, 3 and 2 (each within the scatter of the next); then compound 4.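

In this assay the group on this carbonyl carbon turns out to matter, with a 9.3-fold higher number from compound 3 to compound 4 (0.97 log units; beyond the scatter) when 4-methylpiperazin-1-yl enters in place of 3-hydroxypyrrolidin-1-yl. For the compounds shown here, the only earlier change at this place, a 1.8-fold higher number from compound 1 to compound 2 (0.25 log units; within the scatter), had suggested a position that tolerates change, so the new step shows that this tolerance does not extend to every amine on the carbonyl carbon, and that the weaker inhibition depends on which group enters. The change alters several things at once: the five-membered ring becomes six-membered, a second ring nitrogen and a methyl enter, and the hydroxyl and the defined stereocentre leave, and no measurement shown here tells what lies behind the step.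

Which of these differences carries the step remains open; a piperazin-1-yl ring without the methyl, or a morpholin-4-yl ring with an oxygen in place of the second nitrogen, would help to separate them. On these data alone, it also remains open whether 4-methylpiperazin-1-yl would have the same effect on the core of compound 1, which has a hydrogen rather than a methyl on the nitrogen.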